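Adding a second chloro to the bicyclic core of compound 1

This account rests on a few compounds, and the source may have more. Where it says the series, first, only, none or still open, it means among the compounds named here.

Compound 1 `ClCc1ccc(Cn2cnc3c(Cl)ncnc32)cc1` was tested in a functional assay on KM12 cells (Homo sapiens) for cytotoxicity, read by sulforhodamine B assay, with a stated time of 48 h (on this read-out lower numbers stand for stronger inhibition of growth and higher numbers for weaker inhibition of growth), where compound 1 gave 2140 nM. Among the three measured compounds it holds the second highest number. Compound 2 `ClCc1cccc(Cn2cnc3c(Cl)nc(Cl)nc32)c1` gave 1820 nM in this assay, a number that lies within the scatter of that of compound 1, so no order between the two can be read. Compound 3 `ClCc1cccc(Cn2cnc3nc(Cl)nc(Cl)c32)c1` gave 16600 nM, a higher number than compound 1 by a margin that lies beyond the scatter. Among the measured compounds shown here, neither compound 2 nor compound 3 differs from compound 1 in a single place, so no isolated step is available from the measured set.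

Compound 4 `ClCc1ccc(Cn2cnc3c(Cl)nc(Cl)nc32)cc1` has not yet been measured. It differs from compound 1 by chloro in place of hydrogen on an aromatic carbon. Compound 2 carries the same second chloro on its core and gives a number close to that of compound 1, so the step is expected to be small. The step from compound 1 to compound 4 is estimated as a 1.1-fold lower number from compound 1 to compound 4 (0.05 log units; within the scatter), in no direction beyond the scatter. Compound 4 is therefore expected to give about 1900 nM in this assay, within a range from 700 nM to 5500 nM.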

Compound 4, concentration for 50% growth inhibition: 1820 nM
Compound 4: the middle estimate sits 1.0-fold (0.02 log units) above what was measured, within the range that was stated.
By their numbers in this assay, from the lowest: compounds 2, 4 and 1 (each within the scatter of the next); then compound 3.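

Compound 4 gives the set its first isolated change: chloro in place of hydrogen on an aromatic carbon, between two ring nitrogen atoms, amounts to a 1.2-fold lower number from compound 1 to compound 4 (0.07 log units; within the scatter) in this assay and so cannot be told from no change. Among the compounds shown here, at this position, then, the added chloro leaves the growth-inhibition read-out of compound 1 without a readable shift, a point the earlier compounds could not settle. Nothing available here explains this result.

The compounds shown leave open whether a different group at this same position, such as an amine, a methoxy group or a longer chain, would shift the number beyond the scatter. They also leave open whether the result would hold if the chloromethyl group of compound 4 gave way to a hydroxymethyl group.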